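This account rests on a few compounds, and the source may have more. Where it says the series, first, only, none or still open, it means among the compounds named here.

Measured so far in a functional assay on MCF7 cells (Homo sapiens) for antiproliferative activity (a higher number here means a weaker inhibitor of growth, a lower number a stronger inhibitor of growth), for these compounds:
- compound 1 (`Cc1cc(-c2nc3ccccc3s2)ccc1N`) gives < 0.1 nM as a limit of the assay, not a number
- compound 2 (`COc1ccc(-c2nc3ccccc3s2)cc1OC`) gives 52700 nM
- compound 3 (`COc1ccc(-c2nc3cc(F)ccc3s2)cc1C`) gives 48 nM

Of the two actual numbers, compound 3 has the lower: compound 3 gives 48 nM, while compound 2 gives 52700 nM on the same scale. The gap between these two numbers lies beyond the scatter.

Compound 4 (`COc1ccc(-c2nc3cc(F)ccc3s2)cc1Cl`) has chloro in place of methyl on an aromatic carbon of compound 3, ortho to a methoxy group and meta to a large group (chloro in place of methyl on an aromatic carbon) and otherwise the same structure. Within the data shown here, no measured pair tests this exchange. In this assay no change beyond the scatter is expected, and the estimated 1.6-fold lower number from compound 3 to compound 4 (0.20 log units; within the scatter) leans slightly toward stronger growth inhibition. The expected range is kept wide, as compound 2 at 52700 nM and compound 3 at 48 nM lie far apart in this small set. For compound 4 the estimate is 30 nM with an expected range from 3 nM to 400 nM as the upper end.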

Compound 4, concentration for 50% growth inhibition: 760 nM
Estimate against measurement, compound 4: 25-fold (1.40 log units) below; the whole stated range lies below it.
By their numbers in this assay, from the lowest: compound 3; then compound 4; then compound 2. At a limit, below all of these: compound 1.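

In this assay, the place on the six-membered aromatic ring ortho to a methoxy group and meta to a large group proves sensitive to this exchange: a 16-fold higher number from compound 3 to compound 4 (1.20 log units; beyond the scatter). Among these compounds, this is the first pair that differs in one place, and it shows that chloro in place of methyl is not a neutral swap here, with the stronger growth inhibition staying with the methyl of compound 3. Nothing measured in the series bears on the cause of this step.

As far as these compounds go, whether a bromo, an ethyl or a nitrile at this place would give a value nearer that of compound 3 or of compound 4 remains open, as does whether the step holds in other compounds. Compound 1 gives < 0.1 nM, which is a limit of the assay and not a number, and steps to it cannot be read.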